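Swapping Fluoro for Chloro on a Thromboxane Receptor Antagonist

This account rests on a few compounds, and the source may have more. Where it says the series, first, only, none or still open, it means among the compounds named here.

Measured compounds:
compound 1, `O=C(O)COCCCC[C@@H]1[C@@H](CNS(=O)(=O)c2ccc(F)cc2)CC[C@H]1F`, 650 nM
compound 2, `Cc1ccc(S(=O)(=O)N[C@H]2CCC=C2CCCCOCC(=O)O)cc1`, 1900 nM
compound 3, `O=C(O)CC/C=C\C[C@H]1[C@H](F)CC[C@@H]1NS(=O)(=O)c1ccc(F)cc1`, 750 nM

In a functional assay on a cell-free system (plasma) for inhibition of thromboxane A2 receptor (Homo sapiens), read by turbidimetry (a higher number here means a weaker inhibitor, a lower number a stronger inhibitor), compound 3 gives 750 nM, the second highest of the three numbers. Compound 1, with 650 nM, lies within the scatter of compound 3, so the two cannot be told apart. Compound 2, with 1900 nM, has a number beyond the scatter and higher than that of compound 3. Compound 4, `O=C(O)CC/C=C\C[C@H]1[C@H](F)CC[C@@H]1NS(=O)(=O)c1ccc(Cl)cc1`, is not yet measured; it differs from compound 3 by one change: chloro in place of fluoro on an aromatic carbon. Going by the values given here, no measured pair shows this change, so its effect is unknown here. Compound 4 is expected to sit close to compound 3, with a step of a 1.3-fold lower number from compound 3 to compound 4 (0.10 log units; within the scatter) that stays within the scatter and points clearly in neither direction. Compound 4 is estimated at 600 nM, in a range from 250 nM to 1500 nM.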

Compound 4, half-maximal inhibitory concentration: 210 nM
Estimate against measurement, compound 4: 2.9-fold (0.46 log units) above; measured number outside the range, below it.
By their numbers in this assay, from the lowest: compound 4; then compounds 1 and 3 (each within the scatter of the next); then compound 2.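

In this assay, going by these compounds alone, the change from 4-fluorophenyl to 4-chlorophenyl gives a 3.6-fold lower number from compound 3 to compound 4 (0.55 log units; beyond the scatter), the first step in this set that isolates this position. A single atom on the aromatic carbon para to a large group is therefore enough to shift the number beyond the scatter, with chloro giving the stronger inhibitor of this pair. Nothing shown here explains the shift. As far as these compounds go, whether bromo or methoxy at this position would lower the number further remains open. So does whether chloro would have the same effect on the core of compound 1.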